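This account rests on a few compounds, and the source may have more. Where it says the series, first, only, none or still open, it means among the compounds named here.

Three compounds that share a common core have been examined in an ADME assay for permeability, using PAMPA; on this read-out lower numbers stand for lower permeability and higher numbers for higher permeability. Compound 1 `CCCC[C@H](NC(=O)[C@H](CCCN)NC(=O)[C@H](CCCNC(=N)N)NC(=O)c1ccc(/C=C2\SC(=O)N(Cc3ccccc3)C2=O)cc1)C(N)=O` came out as "impermeable" (no number reported), so no number is available for it. Compound 2 `CCCC[C@H](NC(=O)[C@H](CCCCN)NC(=O)[C@H](CCCNC(=N)N)NC(=O)c1ccc(/C=C2\SC(=S)N(c3ccc(Cl)cc3)C2=O)cc1)C(N)=O` gives 1.02 10^-6 cm/s, and compound 3 `CCCC[C@H](NC(=O)[C@H](CCCCN)NC(=O)[C@H](CCCNC(=N)N)NC(=O)c1ccc(/C=C2\SC(=O)N(CCCC)C2=O)cc1)C(N)=O` gives 1.18 10^-6 cm/s. Compound 2 therefore stands together with compound 3, since the gap between the two numbers lies within the usual scatter of this assay and cannot be read as a real difference, while compound 1 contributes only the statement that it did not pass. Compound 4 `CCCC[C@H](NC(=O)[C@H](CCCCN)NC(=O)[C@H](CCCNC(=N)N)NC(=O)c1ccc(/C=C2\SC(=S)N(C3CCCC3)C2=O)cc1)C(N)=O` has not yet been measured. It differs from compound 2 in one place: cyclopentyl in place of 4-chlorophenyl on an amide-type nitrogen in a ring. Within the data shown here, no pair of measured compounds shows this change, so the data give no direct guide to its effect on the read-out. The step of a 1.0-fold lower number from compound 2 to compound 4 (0.01 log units; within the scatter) is expected to amount to no change beyond the scatter. The estimate for compound 4 is 1 10^-6 cm/s, with a range from 0.4 10^-6 cm/s to 2.5 10^-6 cm/s.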

Compound 4, apparent permeability: 2.31 10^-6 cm/s
For compound 4 the middle estimate is 2.3-fold (0.36 log units) below the measured one, and the stated range covers the measured number.
By their numbers in this assay, from the lowest: compounds 2, 3 and 4 (each within the scatter of the next, the first and the last beyond it).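

In this assay, among these compounds, the group on the amide-type nitrogen in a ring can now be read through a single change for the first time: cyclopentyl in place of 4-chlorophenyl gives a 2.3-fold higher number from compound 2 to compound 4 (0.36 log units; beyond the scatter). This position is therefore not silent, although the step is modest and rests on one pair of compounds. Nothing in the data gives a reason for the rise.

The change swaps an aromatic ring for a non-aromatic one, alters the ring size and removes the chlorine all at once, and the compounds shown cannot separate these parts. Plain phenyl would isolate the chlorine and cyclohexyl the ring size, while a piperidine ring carrying an amine would test whether this position tolerates a charged group.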